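The source may hold more compounds than are shown below. What is called first, only, known or untested is meant among the compounds shown, and "the series" means these compounds.

Compound 1, `O=C(Nc1cccc(-n2cc(-c3ccncc3)c(-c3ccc(Cl)c(O)c3)n2)c1)Nc1cccc(C(F)(F)F)c1`, gives 2240 nM in a functional assay on A498 cells (Homo sapiens) for inhibition, read by sulforhodamine B assay, with a stated time of 48 h; a higher number here means a weaker inhibitor of growth, a lower number a stronger inhibitor of growth.
Compound 2, `COc1cc(-c2nn(-c3cccc(NC(=O)c4cccc(C(F)(F)F)c4)c3)cc2-c2ccncc2)ccc1Cl`, gives 687 nM in this assay.
Compound 3, `COc1cc(-c2nn(-c3cccc(NC(=O)Nc4cccc(C(F)(F)F)c4)c3)cc2-c2ccncc2)ccc1Cl`, gives 958 nM in this assay.

Among these three numbers compound 3 holds the second highest; it sits close to compound 2, with a 1.4-fold higher number from compound 2 to compound 3 (0.14 log units; within the scatter), and further from compound 1, with a 2.3-fold lower number from compound 1 to compound 3 (0.37 log units; beyond the scatter). Compound 4, `COc1cc(-c2nn(-c3cccc(NC(=O)Nc4ccc(Cl)c(C(F)(F)F)c4)c3)cc2-c2ccncc2)ccc1Cl`, has not yet been measured. It differs from compound 3 in one place: chloro in place of hydrogen on an aromatic carbon. Going by the values given here, this change sits on the 3-(trifluoromethyl)phenyl group of the urea, a part of the molecule that none of the measured steps touched. The step from compound 1 to compound 3 altered the oxygen substituent on the other aromatic ring, and the step from compound 2 to compound 3 changed the amide into a urea. Neither tells directly how a chloro group on this ring will act, so the expectation must stay loose. Given that the two measured steps were modest at most, a modest shift, most likely toward a lower number, is expected in this assay. Compound 4 is therefore estimated to give about 600 nM, within a range from 250 nM to 1500 nM. That would mean an expected step of a 1.6-fold lower number from compound 3 to compound 4 (0.20 log units; within the scatter).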

Compound 4, concentration for 50% growth inhibition: 837 nM
Compound 4: the middle estimate sits 1.4-fold (0.14 log units) below what was measured, within the range that was stated.
By their numbers in this assay, from the lowest: compounds 2, 4 and 3 (each within the scatter of the next); then compound 1.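

Going by these compounds alone, the step of a 1.1-fold lower number from compound 3 to compound 4 (0.06 log units; within the scatter) is the first reading on the 3-(trifluoromethyl)phenyl group of the urea, and in this assay it shows that a chloro group at this place, ortho to a trifluoromethyl group and para to a large group, leaves the number indistinguishable from that of the parent compound. The second comparison, a step of a 1.2-fold higher number from compound 2 to compound 4 (0.09 log units; within the scatter), changes the amide partner of compound 2 into the chloro-bearing urea of compound 4 and also stays within the usual scatter, just as the plain urea did in the step of a 1.4-fold higher number from compound 2 to compound 3 (0.14 log units; within the scatter) when set against the same amide. No separate measurement is available that could explain these readings.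

Whether a fluoro group, a nitrile, an amine or a carboxylic acid at this same place would give a different number remains open, since chloro is the only group shown here. Also open, as far as these compounds go, is whether a chloro group at this place would behave the same way on the amide of compound 2, or on the hydroxy-bearing urea of compound 1.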